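Cytotoxicity Outlook for a Nitropyridinyl Analogue

The source may hold more compounds than are shown below. What is called first, only, known or untested is meant among the compounds shown, and "the series" means these compounds.

Compound 1 `O=C(O)c1cccc(-c2ccc(/C=C3\S/C(=N\c4ccccc4)N(c4ncccc4F)C3=O)o2)c1`: > 200000 nM
Compound 2 `O=C(O)c1cccc(-c2ccc(/C=C3\S/C(=N\c4ccccc4)N(c4ccc(F)cn4)C3=O)s2)c1`: > 200000 nM

In an ADME assay on Vero cells (Chlorocebus sabaeus) for cytotoxicity (on this read-out higher numbers stand for lower toxicity in this test and lower numbers for higher toxicity in this test), compound 1 gives > 200000 nM, which is a limit of the assay and not a number. Compound 2 gives > 200000 nM, again a limit. Within the data shown here, both values rest on (the limit of > 200000 nM in this assay, at which 2 of the 2 values shown sit), so compound 2 stands at the limit alongside the only other measured compound. Compound 3 `O=C(O)c1cccc(-c2ccc(/C=C3\S/C(=N\c4ccccc4)N(c4cccnc4[N+](=O)[O-])C3=O)s2)c1` differs from compound 2 by 2-nitropyridin-3-yl in place of 5-fluoropyridin-2-yl on an amide-type nitrogen in a ring. Among the measured compounds shown here, no measured pair shows the effect of this change, so no shift beyond the usual scatter is expected. Compound 3 is estimated at 200000 nM, with a range from 80000 nM to 400000 nM. This expectation corresponds to a number no higher from compound 2 to compound 3 (the limit leaves the size open).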

Compound 3, half-maximal cytotoxic concentration: > 200000 nM
Compound 3: no number, only a limit; the forecaster's own chance of this, stated with the estimate: 70%; the middle value sits exactly at the limit.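

In this assay, among these compounds, compound 3 gives > 200000 nM, a limit and not a number, so no step from compound 2 to compound 3 can be read. The compounds shown leave open which change, if any, would move this read-out off the limit.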